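A second bromo on compound 1

A few compounds are considered here, and "the series" means these few. Any claim that something is new, unique, unknown or untested is made for them only; others in the source may bear on it.

Compound 1 `O=[N+]([O-])c1cc(C(F)(F)F)cc([N+](=O)[O-])c1Oc1ccc(Br)cc1/C=N\OCc1ccccc1F`: 1280 nM
Compound 2 `O=[N+]([O-])c1cc(C(F)(F)F)cc([N+](=O)[O-])c1Oc1ccc(Br)cc1/C=N/OCc1ccccc1Cl`: 3430 nM
Compound 3 `O=[N+]([O-])c1cc(C(F)(F)F)cc([N+](=O)[O-])c1Oc1ccc(Br)cc1/C=N\OCc1ccc(Cl)cc1Cl`: 2060 nM

These values come from a functional assay on A549 cells (Homo sapiens) for antiproliferative activity, read by MTT assay, with a stated time of 48 h; on this read-out lower numbers stand for stronger inhibition and higher numbers for weaker inhibition. Compound 1 has the lowest number of the three, but compound 3 cannot be told apart from it, as a 1.6-fold higher number from compound 1 to compound 3 (0.21 log units; within the scatter) shows. Only compound 2 separates from it, with a 2.7-fold higher number from compound 1 to compound 2 (0.43 log units; beyond the scatter).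

Compound 4 `O=[N+]([O-])c1cc(C(F)(F)F)cc([N+](=O)[O-])c1Oc1c(Br)cc(Br)cc1/C=N\OCc1ccccc1F` is still unmeasured. It differs from compound 1 by bromo in place of hydrogen on an aromatic carbon. Neither measured step adds a bromo, and both alter only the halogens elsewhere in the molecule, so they offer only a rough guide to size. The larger of them is a 2.7-fold higher number from compound 1 to compound 2 (0.43 log units; beyond the scatter), which is modest. No clear shift is therefore expected, and the estimated step is a 1.3-fold higher number from compound 1 to compound 4 (0.10 log units; within the scatter). For compound 4 the expected value is 1600 nM, with an estimated range of 650 nM to 3900 nM.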

Compound 4, half-maximal inhibitory concentration: 1560 nM
Compound 4: middle estimate off by 1.0-fold (0.01 log units), on the high side; measured number inside the range.
By their numbers in this assay, from the lowest: compounds 1, 4, 3 and 2 (each within the scatter of the next, the first and the last beyond it).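

In this assay bromo in place of hydrogen on an aromatic carbon, ortho to a large group, brings a 1.2-fold higher number from compound 1 to compound 4 (0.09 log units; within the scatter) and no shift beyond the scatter. This position, meta to a bromo group, thus takes one more heavy atom without a clear change in the number, something compound 2 and compound 3 could not show, as their halogens differ elsewhere. Nothing given here explains this result.

Going by these compounds, whether a methoxy group or an amine at this position would also leave the number in place stays open. So does whether the second bromo would act the same alongside the 2,4-dichlorophenyl of compound 3.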